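Swapping One Group on a Benzyl Ester Analogue

The source may report more compounds than this note shows. Statements on the series, on what has been measured and on what is new or still open speak of the compounds shown alone.

Of the compounds shown here, three have so far been tested in a functional assay on the whole organism (Tail, strain ICR) with Mus musculus as the target, in the tail flick test, with a stated time of 120 min, at a dose of 25 umol/kg by the oral route; on this read-out lower numbers stand for a weaker effect and higher numbers for a stronger effect at the one dose given. Compound 1 `N=C(N)NCCC[C@H](NC(=O)CN(c1nc(Cl)nc2[nH]cnc12)C1CC1)C(=O)O` gives 17%, compound 2 `CC(C)[C@H](NC(=O)CN(c1nc(Cl)nc2[nH]cnc12)C1CC1)C(=O)OCc1ccccc1` gives 27.3%, and compound 3 `C[C@@H](O)[C@H](NC(=O)CN(c1nc(Cl)nc2[nH]cnc12)C1CC1)C(=O)OCc1ccccc1` gives 30.7%. Compound 3 thus shows the highest of the three numbers, though its gap to compound 2 lies within the usual scatter of such measurements, while its gap to compound 1 lies beyond it.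

The next compound, compound 4 `N=C(N)NCCC[C@H](NC(=O)CN(c1nc(Cl)nc2[nH]cnc12)C1CC1)C(=O)OCc1ccccc1`, has not yet been measured. It differs from compound 3 in one place: a group of 7 heavy atoms (4 carbon, 3 nitrogen; no ring) in place of a group of 3 heavy atoms (2 carbon, 1 oxygen; no ring), on a saturated chain carbon bound to an amide-type nitrogen and a carbonyl carbon. Among the compounds with values here, the incoming group is also present in compound 1, but compound 1 differs from compound 4 elsewhere as well, so no measured step links them directly.

Within the data shown here, only one measured step alters the group at this position: a number 3.4 percentage points higher from compound 2 to compound 3 (within the scatter). That step was small, so on its own it suggests little movement in this assay. Compound 1, which carries the incoming group, gives 17%, which leaves room for a somewhat lower reading. Weighing both, the expected change is a number 6.7 percentage points lower from compound 3 to compound 4 (within the scatter), a modest drop that may not exceed the scatter. Compound 4 is therefore estimated at 24%, in a range from 12% to 38%.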

Compound 4, a percentage reported as activity, at one dose (the size of the read-out at that dose, not a potency): 10.2%
Compound 4: middle estimate off by 13.8 percentage points, on the high side, outside the stated range (below it).
By their numbers in this assay, from the lowest: compounds 4 and 1 (each within the scatter of the next); then compounds 2 and 3 (each within the scatter of the next).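

At this position, on a saturated chain carbon bound to an amide-type nitrogen and a carbonyl carbon, the earlier swap of isopropyl for 1-hydroxyethyl hardly registered in this assay (a number 3.4 percentage points higher from compound 2 to compound 3 (within the scatter)), but the larger nitrogen-rich group of 7 heavy atoms does register, with both (a number 20.5 percentage points lower from compound 3 to compound 4 (beyond the scatter)) and (a number 17.1 percentage points lower from compound 2 to compound 4 (beyond the scatter)) lying beyond the scatter, so the read-out at this place does depend on the group it carries. With this group in place, benzyl in place of hydrogen on an oxygen next to a carbonyl group makes no difference that stands out from the scatter (a number 6.8 percentage points lower from compound 1 to compound 4 (within the scatter)), which means that the two compounds carrying this group sit together at the low end, whether or not the benzyl is present. Nothing measured here explains why the read-out falls with this group.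

The compounds shown leave open which part of the incoming group matters, since a shorter chain or a chain ending in a simple amine at this position would be needed to separate its length from its end. They also leave open whether benzyl matters when isopropyl or 1-hydroxyethyl sits here, which would take the matching free carboxylic acids to show.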